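Amide-to-urea swap on the shared core

The source may hold more compounds than are shown below. What is called first, only, known or untested is meant among the compounds shown, and "the series" means these compounds.

Measured so far:
compound 1 `COc1cc(-c2nn(-c3cccc(NC(=O)Nc4cc(C(F)(F)F)cc(C(F)(F)F)c4)c3)cc2-c2ccncc2)ccc1Cl` gives 1360 nM
compound 2 `COc1cc(-c2nn(-c3cccc(NC(=O)c4cccc(C(F)(F)F)c4)c3)cc2-c2ccncc2)ccc1Cl` gives 1660 nM
compound 3 `O=C(Nc1cccc(-n2cc(-c3ccncc3)c(-c3ccc(Cl)c(O)c3)n2)c1)Nc1cc(C(F)(F)F)cc(C(F)(F)F)c1` gives 1240 nM

In a functional assay on NCI-H226 cells (Homo sapiens) for inhibition, read by sulforhodamine B assay, with a stated time of 48 h (a higher number here means a weaker inhibitor of growth, a lower number a stronger inhibitor of growth), compound 2 has the highest of the three numbers, but it sits within the scatter of compound 1 and of compound 3, so no order among the three can be claimed. Among the compounds with values here, the one single-point step that is measured, a 1.1-fold lower number from compound 1 to compound 3 (0.04 log units; within the scatter), is within the scatter.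

Compound 4 `COc1cc(-c2nn(-c3cccc(NC(=O)Nc4ccc(Cl)c(C(F)(F)F)c4)c3)cc2-c2ccncc2)ccc1Cl` differs from compound 2 by (4-chloro-3-(trifluoromethyl)phenyl)amino in place of 3-(trifluoromethyl)phenyl on a carbonyl carbon. Within the data shown here, no measured step covers this change. Compound 1 and compound 2 differ in the same region of the molecule, a urea against an amide with a different aryl group, and their two values lie within the scatter of each other. Among the measured compounds shown here, the series so far shows only flat numbers; on that basis no step beyond the scatter is expected for this change either.

The expected value for compound 4 is 1350 nM (range 600 nM to 3000 nM), an expected step of a 1.2-fold lower number from compound 2 to compound 4 (0.09 log units; within the scatter) that stays within the scatter.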

Compound 4, concentration for 50% growth inhibition: 1820 nM
Estimate against measurement, compound 4: 1.3-fold (0.13 log units) below; measured number inside the range.
By their numbers in this assay, from the lowest: compounds 3, 1, 2 and 4 (each within the scatter of the next).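

In this assay, (4-chloro-3-(trifluoromethyl)phenyl)amino in place of 3-(trifluoromethyl)phenyl on a carbonyl carbon gives a 1.1-fold higher number from compound 2 to compound 4 (0.04 log units; within the scatter). Within the data shown here, this is the first measured single-place step at this carbonyl carbon, and it shows that this exchange, which brings in a hydrogen-bond donor and a chlorine, does not move the number beyond the scatter. No evidence is available that bears on this result.

The compounds shown leave open whether a different group on this carbonyl carbon, such as a longer alkyl chain or a cyclohexyl ring, would give a step beyond the scatter. Also open, going by these compounds, is whether an amine or a carboxylic acid on the aryl ring of the (4-chloro-3-(trifluoromethyl)phenyl)amino group would do so.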